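A few compounds are considered here, and "the series" means these few. Any claim that something is new, unique, unknown or untested is made for them only; others in the source may bear on it.

Working notes on the series. Among the measured compounds shown here, in an assay on HEK293 cells for binding affinity to Urotensin-2 receptor (Homo sapiens), read by radioligand binding (a lower number here means a stronger inhibitor, a higher number a weaker inhibitor), compound 2, `CC(C)C[C@H](NC(=O)c1cc2ccccc2[nH]1)C(=O)N[C@H]1CCN(Cc2ccc(OCCCN(C)C)cc2)C1`, gives 501 nM; this is the only number reported. Compound 1, `CN(C)CCCOc1ccc(CN2CC[C@H](NC(=O)c3ccc(-c4ccccc4)cc3)C2)cc1`, is recorded in this assay only as < 10000 nM, which is a limit of the assay rather than a number, as noted in the limit of < 10000 nM in this assay, at which 1 of the 2 values shown sits. For the measured compounds named here, no step between two measured compounds is available, so the size of the change to come has no direct precedent in these data.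

Compound 3, `CC(C)C[C@H](NC(=O)c1ccc(Br)cc1)C(=O)N[C@H]1CCN(Cc2ccc(OCCCN(C)C)cc2)C1`, differs from compound 2 by 4-bromophenyl in place of 1H-indol-2-yl on a carbonyl carbon. Going by the values given here, on this single change, a shift toward weaker binding in this assay is expected, of modest size and probably beyond the scatter, but with wide uncertainty given that only one number anchors the series. The expected step is a 3.0-fold higher number from compound 2 to compound 3 (0.48 log units; beyond the scatter). Compound 3 is accordingly estimated in this assay at 1500 nM, with a plausible range from 300 nM to 8000 nM.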

Compound 3, inhibition constant: 200 nM
Estimate against measurement, compound 3: 7.5-fold (0.88 log units) above, and the stated range ends above it.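

Set on a carbonyl carbon, 4-bromophenyl in place of 1H-indol-2-yl gives a 2.5-fold lower number from compound 2 to compound 3 (0.40 log units; beyond the scatter) in this assay, the first step that can be read in the series. In this one pair, a group with one six-membered aromatic ring of carbon only and no hydrogen-bond donor binds more strongly than the group with two aromatic rings and one hydrogen-bond donor, so neither the five-membered ring nor that donor is required for binding at this level. Nothing measured here bears on why the number moved in this direction.

Still open, on these data alone, is what the bromine itself contributes: plain phenyl, 4-chlorophenyl or 4-methoxyphenyl on the same carbonyl carbon would separate the halogen from the ring. Equally open, as far as these compounds go, is whether this step holds when the dimethylamino group of the shared core is replaced by a pyrrolidine or a primary amine.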